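From compound 3 to compound 4: one side chain replaced

This account rests on a few compounds, and the source may have more. Where it says the series, first, only, none or still open, it means among the compounds named here.

Of the compounds shown here, three sharing one core have been measured in a functional assay on FM3A cells (Mus musculus) for cytotoxicity; a lower number here means that less compound is needed, a higher number that more compound is needed for the effect. Compound 1 `CCCOOC1(OOCCC)CCCCCCCCCCC1` gives 12000 nM, compound 2 `C=C(C)COOC1(OOCC(=C)C)CCCCCCCCCCC1` gives 38000 nM, and compound 3 `COOC1(OOC(C)(C)OC)CCCCCCCCCCC1` gives 7300 nM. Compound 3 stands within the scatter of compound 1, while the number for compound 2 is higher than that of compound 3 by more than the scatter. No two of these compounds differ in one place only, so the series offers no measured single-change step to carry over.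

Compound 4 `COOC1(OOCCC(=O)OC)CCCCCCCCCCC1` keeps the core of compound 3 and alters one side chain: 2-(methoxycarbonyl)ethyl in place of 1-methoxy-1-methylethyl on an oxygen. In words, 2-(methoxycarbonyl)ethyl stands in place of 1-methoxy-1-methylethyl on an oxygen. Going by the values given here, with no direct precedent for this change, the expectation rests only on the span of the measured numbers, from compound 3 at 7300 nM to compound 2 at 38000 nM. A new number inside that span seems most likely, with no large departure in this assay. The estimated change is a 1.8-fold higher number from compound 3 to compound 4 (0.25 log units; within the scatter), an expected move to a higher number that stays within the scatter. For compound 4 the estimated value is 13000 nM, with an expected range of 4000 nM to 40000 nM.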

Compound 4, half-maximal effective concentration: 1400 nM
Beside the measured number, compound 4's estimate is 9.3-fold (0.97 log units) above it, outside the stated range (below it).
By their numbers in this assay, from the lowest: compound 4; then compounds 3 and 1 (each within the scatter of the next); then compound 2.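

In this assay the step gives the series its first single-change reading: 2-(methoxycarbonyl)ethyl in place of 1-methoxy-1-methylethyl on an oxygen gives a 5.2-fold lower number from compound 3 to compound 4 (0.72 log units; beyond the scatter) with the rest of the structure unchanged. Going by these compounds alone, this shows that the number responds to this side chain alone by more than the scatter, which the earlier compounds could not show because none of them differed in one place only. The entering and leaving groups differ at once in heavy atoms, hydrogen-bond acceptors and a double bond outside aromatic rings, and no measurement available here explains the drop or separates these differences.

From the compounds shown here alone, it remains open whether the lower number depends on the methyl ester itself, as a carboxylic acid or an amide at the end of the same chain would test, or on the distance to the carbonyl, as a longer chain would test. Going by these compounds, it is also open whether the same replacement gives a step of similar size when the other side chain is propyl rather than methyl.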